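The source may hold more compounds than are shown below. What is called first, only, known or untested is meant among the compounds shown, and "the series" means these compounds.

Compound 1 `CCC[C@@H]1O[C@H](COCc2ccccc2)[C@H](OCc2ccccc2)[C@H](OCc2ccccc2)[C@H]1O`: "not active" (no number reported) in a functional assay on HL-60 cells (Homo sapiens) for antiproliferative activity, read by MTT assay; on this read-out higher numbers stand for weaker inhibition and lower numbers for stronger inhibition.
Compound 2 `CCC[C@@H]1O[C@H](COCc2ccccc2)[C@@H](OCc2ccccc2)[C@H](OCc2ccccc2)[C@H]1O`: 11700 nM in this assay.
Compound 3 `CCC[C@H]1O[C@H](COCc2ccccc2)[C@@H](OCc2ccccc2)[C@H](OCc2ccccc2)[C@H]1O`: 28200 nM in this assay.

Compound 2 holds the lower of the two numbers in this assay; compound 3 stands at a 2.4-fold higher number from compound 2 to compound 3 (0.38 log units; beyond the scatter), and compound 1 has no number at all. Compound 4 `C=C[C@@H]1O[C@H](COCc2ccccc2)[C@@H](OCc2ccccc2)[C@H](OCc2ccccc2)[C@H]1O` differs from compound 2 in a single place: vinyl in place of propyl on a saturated ring carbon. Among the compounds with values here, the one measured step rests on configuration alone the fact that compounds 2 and 3 differ only in the configuration as drawn and so says nothing about an exchange of side chain; no measured step bears on this change. For compound 4 the expected step is therefore a 1.2-fold higher number from compound 2 to compound 4 (0.08 log units; within the scatter), within the scatter, in no firm direction. The estimate for compound 4 in this assay is 14000 nM, with a range from 5000 nM to 45000 nM.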

Compound 4, half-maximal inhibitory concentration: 11800 nM
Compound 4: the middle estimate sits 1.2-fold (0.07 log units) above what was measured; low and high end bracket the measured number.
By their numbers in this assay, from the lowest: compounds 2 and 4 (each within the scatter of the next); then compound 3.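

At this saturated ring carbon, next to the ring oxygen, vinyl in place of propyl makes no difference that this assay can separate (a 1.0-fold higher number from compound 2 to compound 4 (0.00 log units; within the scatter)). The earlier compounds shown here spoke only to configuration, whereas this pair exchanges the side chain itself while keeping the configuration drawn for compound 2. No evidence at hand bears on this exchange. From the compounds shown here alone, whether a longer chain such as hexyl, or an amine, at this carbon would shift the number stays open. So does whether vinyl would behave the same way on the configuration of compound 3.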